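Acyl exchange on the amide: compound 3 to compound 4

The source may hold more compounds than are shown below. What is called first, only, known or untested is meant among the compounds shown, and "the series" means these compounds.

- compound 1 `COc1cc(/C=C/C(=O)c2cccc(NC(=O)c3c(Cl)cccc3Cl)c2)ccc1O`: 2.48 ug/mL
- compound 2 `COc1cc(/C=C/C(=O)c2cccc(NC(=O)c3cc(Cl)cc(Cl)c3)c2)ccc1O`: > 50 ug/mL (a limit)
- compound 3 `COc1cc(/C=C/C(=O)c2cccc(NC(=O)C(C)C)c2)ccc1O`: 3.47 ug/mL

In a functional assay on Vero cells (Chlorocebus sabaeus) for inhibition (a lower number here means a stronger inhibitor, a higher number a weaker inhibitor), compound 3 has the higher of the two numbers, but the gap is within the scatter: a 1.4-fold higher number from compound 1 to compound 3 (0.15 log units; within the scatter). The value of compound 2 is a limit.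

Compound 4 `CCOC(=O)C(=O)Nc1cccc(C(=O)/C=C/c2ccc(O)c(OC)c2)c1` carries ethoxycarbonyl in place of isopropyl on a carbonyl carbon. Exchanges at this carbonyl carbon have given both outcomes: a 1.4-fold higher number from compound 1 to compound 3 (0.15 log units; within the scatter) is small, whereas an at least 20-fold higher number from compound 1 to compound 2 (1.30 log units; beyond the scatter) and an at least 14-fold lower number from compound 2 to compound 3 (1.15 log units; beyond the scatter) are large. The size of the next step is therefore uncertain, and a wide range is needed. The expected step is small and towards a higher number, a 1.4-fold higher number from compound 3 to compound 4 (0.16 log units; within the scatter). The estimate for compound 4 is 5 ug/mL, with an expected range of 1.2 ug/mL to 25 ug/mL.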

Compound 4, half-maximal inhibitory concentration: > 50 ug/mL
Compound 4 gave a limit, no number (the forecaster's own chance of this, stated with the estimate: 10%); middle value at least 10-fold (1.00 log units) from the limit.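

In this assay, ethoxycarbonyl on this carbonyl carbon gives a large change from the small isopropyl group: an at least 14-fold higher number from compound 3 to compound 4 (1.15 log units; beyond the scatter), and an at least 20-fold higher number from compound 1 to compound 4 (1.30 log units; beyond the scatter). Having no ring therefore does not by itself keep the number low, since isopropyl and ethoxycarbonyl, both without a ring, fall on opposite sides of this step. The step between compound 2 and compound 4 cannot be read, as both values are limits: the limit of > 50 ug/mL in this assay, at which 2 of the 4 values shown sit.

The compounds shown do not separate the ester from the added carbonyl. From the compounds shown here alone, it remains open whether a carboxylic acid or a simple methyl group on this carbonyl carbon would track compound 3 or compound 4.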